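Replacing the 2-aminoethyl chain of compound 1

A few compounds are considered here, and "the series" means these few. Any claim that something is new, unique, unknown or untested is made for them only; others in the source may bear on it.

In a functional assay on MDA-MB-435 cells (Homo sapiens) for cytotoxicity, read by MTT assay, with a stated time of 72 h (a higher number here means a weaker inhibitor, a lower number a stronger inhibitor), compound 1 `NCCNc1c(C(=O)NCc2ccc(F)cc2)nc(Br)c2cccnc12` gives 12000 nM, the higher of the two numbers in hand. Compound 3 `CN(C)c1ccc(CNC(=O)c2nc(Br)c3cccnc3c2N[C@H]2CC[C@H](N)CC2)cc1` gives 4000 nM, a gap beyond the scatter. Compound 2 `O=C(NCCCNc1c(C(=O)NCc2ccc(F)cc2)nc(Br)c2cccnc12)c1ccccc1` reaches only the limit > 20000 nM in this assay, a limit and not a number. Within the data shown here, the single measured step that bears on the new compound is an at least 1.6-fold higher number from compound 1 to compound 2 (0.22 log units; that floor lies within the scatter): the amino group of compound 1 is capped, and the value runs into (the limit of > 20000 nM in this assay, at which 1 of the 3 values shown sits). Compound 4 `C[C@H](Nc1c(C(=O)NCc2ccc(F)cc2)nc(Br)c2cccnc12)c1ccccc1` carries 1-phenylethyl in place of 2-aminoethyl on a nitrogen on an aromatic ring; the nitrogen of the 2-aminoethyl chain is lost and a phenyl ring comes in. Among the compounds in hand, compound 3 keeps a free amine and gives the lower number, compound 2 loses it and gives only a limit. For compound 4 a rise is therefore expected, a 1.5-fold higher number from compound 1 to compound 4 (0.18 log units; within the scatter), with a fair chance that only a limit is returned. Compound 4 is estimated at 18000 nM, between 7000 nM and 45000 nM.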

Compound 4, half-maximal inhibitory concentration: > 20000 nM
Compound 4 gave a limit, no number; the forecaster's own chance of this, stated with the estimate: 40%; middle value at least 1.1-fold (0.04 log units) away from the limit.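

In this assay, the change to 1-phenylethyl gives an at least 1.6-fold higher number from compound 1 to compound 4 (0.22 log units; that floor lies within the scatter), so its true size at this nitrogen on an aromatic ring stays unread. Compound 2 showed a limit only for a capped amine; compound 4 shows that a side chain with no amine nitrogen and a phenyl ring also returns a limit and no number: the limit of > 20000 nM in this assay, at which 2 of the 4 values shown sit.

Open, as far as these compounds go, is whether a 3-aminopropyl chain on the same nitrogen gives a lower number than compound 1. Also open, from the compounds shown here alone, is whether an amine on the phenyl ring of the 1-phenylethyl group returns a measurable number.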